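From 1-methylcyclopropyl to cyclobutyl on an amide-type nitrogen

The source may report more compounds than this note shows. Statements on the series, on what has been measured and on what is new or still open speak of the compounds shown alone.

In an in vivo ADME assay on the whole organism (strain Sprague-Dawley) for pharmacokinetics, with Rattus norvegicus as the target, at a dose of 10 mg/kg by the oral route (a lower number here means that a smaller share of the oral dose reaches the circulation, a higher number that a larger share of the oral dose reaches the circulation), compound 1 (`CC(C)(CC(=O)O)c1ccc(-c2cccc(-n3cc(C(=O)NC4CC4)c(=O)c4cccnc43)c2)cc1`) gives 62% and compound 2 (`CC1(NC(=O)c2cn(-c3cccc(-c4ccc(C5CC5C(=O)O)cc4)c3)c3ncccc3c2=O)CC1`) gives 58% on the same scale. For the measured compounds named here, compound 2 thus stands within the usual scatter of compound 1, the only other compound with a number so far. Compound 3 (`O=C(NC1CCC1)c1cn(-c2cccc(-c3ccc(C4CC4C(=O)O)cc3)c2)c2ncccc2c1=O`) has the same atoms as compound 2, joined differently, with one change: cyclobutyl in place of 1-methylcyclopropyl on an amide-type nitrogen. Going by the values given here, no pair of measured compounds differs in a single place, so no measured step can guide the expectation. The nearest evidence is that compound 1 at 62% and compound 2 at 58% lie within the scatter of each other, although they differ in more than one place. A large step is therefore not expected here, and the estimate is a number 4 percentage points lower from compound 2 to compound 3 (within the scatter) in this assay as a small move downward, none beyond the scatter. Compound 3 is expected at 54% in this estimate, with 36% to 70% as its range.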

Compound 3, oral bioavailability: 20%
For compound 3 the middle estimate is 34 percentage points above the measured one; measured number below the stated range.
By their numbers in this assay, from the lowest: compound 3; then compounds 2 and 1 (each within the scatter of the next).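

In this assay, for the compounds shown here, replacing 1-methylcyclopropyl with cyclobutyl on the amide-type nitrogen gives a number 38 percentage points lower from compound 2 to compound 3 (beyond the scatter), the first step that can be read at a single place, and it is a large one. The two groups match in what is counted for them: each has the same number of heavy atoms, all of them carbon, with no hydrogen-bond donors or acceptors and no net charge, so these counts do not separate them, yet the oral bioavailability does, and this position is thus sensitive to how those same carbon atoms are arranged. No measurement at hand explains the drop.

Open, going by these compounds, is whether a tert-butyl or a cyclopentyl group on the same amide-type nitrogen would stay close to compound 2 or drop toward compound 3, which would show how narrow the tolerance at this position is. Going by these compounds alone, also open is whether the same change would cost as much with a different carboxylic acid side chain on the shared core, since only this one pair carries it.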